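A few compounds are considered here, and "the series" means these few. Any claim that something is new, unique, unknown or untested is made for them only; others in the source may bear on it.

Measured in an ADME assay on HPLF cells (Homo sapiens) for cytotoxicity, with a stated time of 24 h; on this read-out higher numbers stand for lower toxicity in this test and lower numbers for higher toxicity in this test:
- Compound 1 `O=C1/C(=C/c2ccccc2)CCC/C1=C\c1cccc([N+](=O)[O-])c1` gives 18000 nM
- Compound 2 `O=C1/C(=C/c2ccccc2)CCC/C1=C\c1ccc([N+](=O)[O-])cc1` gives 282000 nM
- Compound 3 `O=C1/C(=C/c2ccc(F)cc2)CCC/C1=C\c1ccc([N+](=O)[O-])cc1` gives > 400000 nM, a limit and not a number

Compound 3 therefore has no exact place on the scale: it stands at the limit of > 400000 nM in this assay, at which 1 of the 3 values shown sits, and nothing more can be said of its position. Compound 4 `O=C1/C(=C/c2ccc(Cl)cc2)CCC/C1=C\c1ccc([N+](=O)[O-])cc1` differs from it by chloro in place of fluoro on an aromatic carbon. Within the data shown here, the only measured step at this place, fluoro in place of hydrogen, is an at least 1.4-fold higher number from compound 2 to compound 3 (0.15 log units; that floor lies within the scatter) and sets no firm size. No step beyond the scatter is therefore expected in this assay, in either direction. The estimate amounts to an expected at least 1.1-fold lower number from compound 3 to compound 4 (0.05 log units; that floor lies within the scatter) overall. For compound 4 the estimated value is 350000 nM, with an expected range from 150000 nM to 800000 nM here.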

Compound 4, half-maximal cytotoxic concentration: 332000 nM
The estimate for compound 4 lay 1.1-fold (0.02 log units) above the measured number, within the range that was stated.
By their numbers in this assay, from the lowest: compound 1; then compounds 2 and 4 (each within the scatter of the next). At a limit, above all of these: compound 3.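

In this assay, set against hydrogen, chloro gives a 1.2-fold higher number from compound 2 to compound 4 (0.07 log units; within the scatter), so at this place, para to a large group, a halogen larger than fluoro cannot be told apart from hydrogen. Against fluoro, the change reads an at least 1.2-fold lower number from compound 3 to compound 4 (0.08 log units; that floor lies within the scatter), which sets only a floor. Compound 3 gives a limit and not a number: the limit of > 400000 nM in this assay, at which 1 of the 4 values shown sits.

The compounds shown leave open how an amine or a carboxylic acid would read at this place. They also leave open whether chloro would read alike on the core of compound 1.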